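The compounds below may be only part of what the source reports. "The series", "measured", "known", "first", "only" and "open" are said of these compounds alone.

In an ADME assay on Vero cells (Chlorocebus sabaeus) for cytotoxicity, read by MTT assay, with a stated time of 24 h; on this read-out higher numbers stand for lower toxicity in this test and lower numbers for higher toxicity in this test:
- Compound 1 `Cn1nc(C(F)(F)F)cc1C(=O)Nc1ccc(S(=O)(=O)c2ccccc2CO)cc1`: > 75000 nM, a limit
- Compound 2 `Cn1nc(C(F)(F)F)cc1C(=O)Nc1ccc(S(=O)(=O)N2CCCCC2CO)cc1`: > 75000 nM, a limit

Compound 2 therefore has no exact number, only a limit, and the same is true of the only other result: the limit of > 75000 nM in this assay, at which 2 of the 2 values shown sit. Compound 3 `Cn1nc(C(F)(F)F)cc1C(=O)Nc1ccc(S(=O)(=O)c2ccccc2)cc1` differs from compound 2 on the sulfonyl sulfur, with phenyl in place of 2-(hydroxymethyl)piperidin-1-yl on a sulfonyl sulfur. Among the compounds with values here, the one measured exchange at this place is a step that the two limits leave unreadable from compound 1 to compound 2, so it offers no size to carry over. Compound 1, whose group on the sulfonyl sulfur is 2-(hydroxymethyl)phenyl, gives > 75000 nM, which is also a limit. No clear step is therefore expected in this assay, in either direction, and another limit is the likeliest report. The expected step is a step that the limit leaves unreadable from compound 2 to compound 3. The estimate for compound 3 is 80000 nM, with an expected range from 30000 nM to 200000 nM.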

Compound 3, half-maximal cytotoxic concentration in the Vero assay: > 75000 nM
Compound 3 gave a limit, no number; the forecaster's own chance of this, stated with the estimate: 70%; the middle value lies beyond the limit too.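

In the Vero assay, compound 3 gives > 75000 nM, a limit. Within the data shown here, compound 1 and compound 2 also give only limits, so no step between these compounds can be read: the limit of > 75000 nM in the Vero assay, at which 3 of the 3 values shown sit. As far as these compounds go, what stays open is whether the group on the sulfonyl sulfur affects toxicity in this test at any higher concentration. In a physicochemical assay for solubility, read by nephelometry, at pH 7.4 (a lower number here means a less soluble compound, a higher number a more soluble compound), compound 2 gives 61 ug/mL and compound 3 gives 22 ug/mL, which is a 2.8-fold lower number from compound 2 to compound 3 (0.44 log units; beyond the scatter).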